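A few compounds are considered here, and "the series" means these few. Any claim that something is new, unique, unknown or untested is made for them only; others in the source may bear on it.

Among the measured compounds shown here, compound 1 `CS(=O)(=O)c1ccc(Cc2nnc3n2N=C(c2ccccc2)CS3)cc1` is the parent of the two compounds measured so far. In a functional assay on RAW264.7 cells (Mus musculus) for cytotoxicity, read by MTT assay, with a stated time of 48 h, tested at 12.5 uM (a higher number here means a stronger effect of the compound at the concentration tested, a lower number a weaker effect), compound 1 gives 42%, the lower of the two numbers in hand. For the measured compounds named here, its one measured neighbour is compound 2 `CS(=O)(=O)c1ccc(Cc2nnc3n2N=C(c2ccc(-c4ccccc4)cc2)CS3)cc1`, which in this assay gives 58.2%; the step of a number 16.2 percentage points higher from compound 1 to compound 2 (beyond the scatter) comes from phenyl in place of hydrogen on an aromatic carbon. Compound 3 `CS(=O)(=O)c1ccc(Cc2nnc3n2N=C(c2cc(Cl)sc2S(N)(=O)=O)CS3)cc1` has not been measured. It differs from compound 1 by 5-chloro-2-sulfamoylthiophen-3-yl in place of phenyl on a carbon with a double bond to nitrogen. Going by the values given here, no measured step concerns this change: the single step available, a number 16.2 percentage points higher from compound 1 to compound 2 (beyond the scatter), adds a phenyl on an aromatic carbon rather than replacing the phenyl on the carbon with a double bond to nitrogen, so it offers no direction for compound 3. The step of a number 3 percentage points higher from compound 1 to compound 3 (within the scatter) is therefore expected to stay within the scatter, with wide uncertainty in both directions. Compound 3 is estimated to give 45% in this assay, in a range from 25% to 65%.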

Compound 3, a percentage reported as activity, at one concentration (the size of the read-out at that concentration, not a potency): 22.8%
The estimate for compound 3 lay 22.2 percentage points above the measured number, outside the stated range (below it).
By their numbers in this assay, from the lowest: compound 3; then compound 1; then compound 2.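

At the carbon with a double bond to nitrogen, the phenyl is not a freely exchangeable group in this assay: 5-chloro-2-sulfamoylthiophen-3-yl gives a number 19.2 percentage points lower from compound 1 to compound 3 (beyond the scatter). This change runs opposite in direction to the earlier addition of phenyl on an aromatic carbon, a number 16.2 percentage points higher from compound 1 to compound 2 (beyond the scatter), so the two changes to the aryl part of compound 1 have now moved the read-out both up and down. Nothing available bears on why the number falls at this position.

Still open, going by these compounds, is which part of the entering group carries the step, since the thiophene ring, chlorine and sulfamoyl all enter together; a 2-sulfamoylthiophen-3-yl without chlorine and a 5-chlorothiophen-3-yl without sulfamoyl would separate them. Also open, on these data alone, is how a carboxylic acid or an amine on this carbon would read.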